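Adding One Methyl Group to Compound 1

The source may report more compounds than this note shows. Statements on the series, on what has been measured and on what is new or still open speak of the compounds shown alone.

In a functional assay on 786-0 cells (Homo sapiens) (on this read-out lower numbers stand for stronger inhibition of growth and higher numbers for weaker inhibition of growth), compound 1 (`COc1ccccc1-c1cc(O)c2cccnc2n1`) gives 36300 nM and compound 2 (`COc1ccccc1-c1cc(O)c2c(C)ccnc2n1`) gives 60300 nM so these two values lie within the scatter of each other. Compound 3 (`COc1ccccc1-c1cc(O)c2cc(C)cnc2n1`) has not yet been measured. Its difference from compound 1 (methyl in place of hydrogen on an aromatic carbon) is a methyl in place of hydrogen on an aromatic carbon, two atoms from the ring nitrogen. Within the data shown here, the one comparable measured change is a 1.7-fold higher number from compound 1 to compound 2 (0.22 log units; within the scatter) and it stays within the scatter. No step beyond the scatter is therefore expected in this assay here. Compound 3 is expected near 45000 nM with an estimated range from 20000 nM to 100000 nM in that read-out. The expected step is a 1.2-fold higher number from compound 1 to compound 3 (0.09 log units; within the scatter) on this estimate.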

Compound 3, concentration for 50% growth inhibition: 41700 nM
The estimate for compound 3 lay 1.1-fold (0.03 log units) above the measured number; the measured number falls inside the stated range.
By their numbers in this assay, from the lowest: compounds 1, 3 and 2 (each within the scatter of the next).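

In this assay, placing a methyl two atoms from the ring nitrogen gives a 1.1-fold higher number from compound 1 to compound 3 (0.06 log units; within the scatter) and so stays within the scatter. A second ring position, distinct from the one carrying the methyl in compound 2, therefore accepts this small addition with no measurable shift in growth inhibition. Nothing available explains this result. As far as these compounds go, whether a larger group, such as a longer alkyl chain or an amine, would shift the number beyond the scatter at this position remains open. A carboxylic acid here is equally unresolved.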